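The compounds below may be only part of what the source reports. "The series", "measured", "known", "first", "only" and "open" are said of these compounds alone.

Among the compounds with values here, in a functional assay on the whole organism (strain albino) with Mus musculus as the target, with a stated time of 0.5 h (a higher number here means that more compound is needed for the effect, a lower number that less compound is needed), compound 2 `CC(=O)N1N=C(Nc2nc3ccc(C)cc3s2)CC1c1ccc(Cl)cc1` gives 27.5 umol/kg, and compound 1 `COc1ccc(C2CC(Nc3nc4ccc(C)cc4s3)=NN2C(C)=O)cc1`, the only other compound measured, gives 39.4 umol/kg, so the two stand level. Compound 3 `CC(=O)N1N=C(Nc2nc3ccc(C)cc3s2)CC1c1ccccc1` has hydrogen in place of chloro on an aromatic carbon. Within the data shown here, one measured step bears on this, the swap that brought in the same chloro, and it amounts to a 1.4-fold lower number from compound 1 to compound 2 (0.16 log units; within the scatter). Among the measured compounds shown here, with only that small step as a guide, no change beyond the scatter is expected in this assay, and the expected result is a 1.2-fold higher number from compound 2 to compound 3 (0.08 log units; within the scatter). For compound 3 the estimated value is 33 umol/kg, with an expected range from 15 umol/kg to 70 umol/kg.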

Compound 3, dose for half-maximal effect: 112 umol/kg
Beside the measured number, compound 3's estimate is 3.4-fold (0.53 log units) below it; measured number outside the range, above it.
By their numbers in this assay, from the lowest: compounds 2 and 1 (each within the scatter of the next); then compound 3.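

In this assay there is a 4.1-fold higher number from compound 2 to compound 3 (0.61 log units; beyond the scatter) and a 2.8-fold higher number from compound 1 to compound 3 (0.45 log units; beyond the scatter) once the group on this aromatic carbon gives way to hydrogen. Chloro and methoxy stood level, so only now does it appear that having one of these groups here counts for more than which one it is. Nothing measured here explains this difference. Still open, as far as these compounds go, is whether fluoro, methyl or an amine on the same carbon would keep the lower number, and so what chloro and methoxy share that matters here.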